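Swapping the Phenyl Substituent: From Bromo to Methoxy

This account rests on a few compounds, and the source may have more. Where it says the series, first, only, none or still open, it means among the compounds named here.

Measured compounds:
compound 1, `Fc1ccc(-c2cn3ccnc3c(-c3ccc4ncn(C5CCCCC5)c4c3)n2)cc1`, 7.93%
compound 2, `Brc1ccc(-c2cn3ccnc3c(-c3ccc4ncn(C5CCCCC5)c4c3)n2)cc1`, 41.3%

Within the data shown here, in a functional assay on SF-295 cells (Homo sapiens) for inhibition, read by sulforhodamine B assay, with a stated time of 48 h, tested at 10 uM (a lower number here means less inhibition, a higher number more inhibition at the concentration tested (going by the name of the read-out)), compound 2 gives 41.3%, the higher of the two numbers so far; compound 1 gives 7.93%. Among the measured compounds shown here, the single measured step, a number 33.4 percentage points higher from compound 1 to compound 2 (beyond the scatter), shows that the substituent on the phenyl ring alone can shift the read-out well beyond the scatter. Compound 3, `COc1ccccc1-c1cn2ccnc2c(-c2ccc3ncn(C4CCCCC4)c3c2)n1`, has not yet been tested in this assay. It differs from compound 2 in one place: 2-methoxyphenyl in place of 4-bromophenyl on an aromatic carbon. For the measured compounds named here, no measured step covers a 2-methoxyphenyl group, so the direction cannot be read from the data; the only hint is that compound 1, carrying a different phenyl substituent, gave 7.93%. The step is therefore expected to be a number 21.3 percentage points lower from compound 2 to compound 3 (beyond the scatter), with wide uncertainty. Compound 3 is estimated at 20%, within 0% to 50%.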

Compound 3, a percentage reported as inhibition, at one concentration (the size of the read-out at that concentration, not a potency): 9.76%
Beside the measured number, compound 3's estimate is 10.2 percentage points above it; measured number inside the range.
By their numbers in this assay, from the lowest: compounds 1 and 3 (each within the scatter of the next); then compound 2.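

In this assay, the higher read-out of compound 2 did not carry over to this other phenyl group at the same aromatic carbon, with a number 31.5 percentage points lower from compound 2 to compound 3 (beyond the scatter) when 2-methoxyphenyl took the place of 4-bromophenyl. Set against the 4-fluorophenyl group, the same 2-methoxyphenyl group gives a number 1.8 percentage points higher from compound 1 to compound 3 (within the scatter), so these two groups cannot be told apart here, and among the three compounds only the 4-bromophenyl group stands apart. Nothing available here explains this difference.

Compound 3 changes both the substituent and its place on the phenyl ring, so it remains open which of the two accounts for the step. Also open, from the compounds shown here alone, is how a chloro group, an amine or a carboxylic acid on that phenyl ring would read in this assay at this position.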